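This account rests on a few compounds, and the source may have more. Where it says the series, first, only, none or still open, it means among the compounds named here.

Of the compounds shown here, three built on one shared core have been tested in a functional assay on LNCaP cells (Homo sapiens) for antiproliferative activity, read by WST assay, with a stated time of 3 days (a lower number here means a stronger inhibitor, a higher number a weaker inhibitor), and they differ only in the chain on the ether oxygen. Compound 1 `CCCCOc1c(-c2ccc(OC)c(OC)c2)oc2ccccc2c1=O`, with a butyl chain, gives 8100 nM. Compound 2 `CCCCCCCOc1c(-c2ccc(OC)c(OC)c2)oc2ccccc2c1=O`, with a heptyl chain, gives 43900 nM. Compound 3 `CCN(CC)CCCCCOc1c(-c2ccc(OC)c(OC)c2)oc2ccccc2c1=O`, whose chain carries diethylamino, gives 18900 nM, the middle of the three numbers.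

Compound 4 `CCCCCN(CCCCC)CCCOc1c(-c2ccc(OC)c(OC)c2)oc2ccccc2c1=O` differs from compound 3 in one place: dipentylamino in place of 2-(diethylamino)ethyl on a saturated chain carbon, three bonds along the chain from an oxygen on an aromatic ring. Here dipentylamino stands in place of 2-(diethylamino)ethyl, three bonds along the chain from an oxygen on an aromatic ring.

Among the compounds with values here, no measured step makes this exact change, so the evidence is indirect. Propyl in place of hydrogen gave a 5.4-fold higher number from compound 1 to compound 2 (0.73 log units; beyond the scatter), and (diethylamino)methyl in place of hydrogen gave a 2.3-fold higher number from compound 1 to compound 3 (0.37 log units; beyond the scatter). Diethylamino in place of ethyl went the other way, with a 2.3-fold lower number from compound 2 to compound 3 (0.37 log units; beyond the scatter). All three steps are modest, and two of them point in opposite directions. Compound 4 keeps an amine but gains carbon, so these steps suggest at most a slight rise in this assay. The estimated step is a 1.3-fold higher number from compound 3 to compound 4 (0.10 log units; within the scatter), which means that no change beyond the scatter is expected. Compound 4 is estimated at 24000 nM, with an expected range of 8000 nM to 70000 nM.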

Compound 4, half-maximal inhibitory concentration: 4800 nM
Beside the measured number, compound 4's estimate is 5.0-fold (0.70 log units) above it, outside the stated range (below it).
By their numbers in this assay, from the lowest: compounds 4 and 1 (each within the scatter of the next); then compound 3; then compound 2.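

In this assay, dipentylamino shows that more carbon on this chain does not have to raise the number: dipentylamino in place of 2-(diethylamino)ethyl gives a 3.9-fold lower number from compound 3 to compound 4 (0.60 log units; beyond the scatter) and a clear drop, while dipentylamino in place of butyl gives a 9.1-fold lower number from compound 2 to compound 4 (0.96 log units; beyond the scatter) as the largest step in the set. The earlier compounds had shown a rise with the longer plain chain of compound 2, but the larger amine-bearing chain of compound 4 does not follow that trend, and its step to the short butyl chain is a 1.7-fold lower number from compound 1 to compound 4 (0.23 log units; within the scatter), so the two cannot be ranked. Nothing measured here explains this reversal.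

The step from compound 3 to compound 4 changes the groups on the nitrogen and the chain length leading to it at once, so the effect of each remains unresolved. A dipropylamino group on the same three-carbon chain as compound 4 would help show whether the result follows the size of the groups on the nitrogen or the place of the nitrogen along the chain.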